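This account rests on a few compounds, and the source may have more. Where it says the series, first, only, none or still open, it means among the compounds named here.

In an assay on HEK293 cells for displacement of a labelled ligand from metabotropic glutamate receptor 5 (Homo sapiens), with a stated time of 2 h (a higher number here means a weaker inhibitor, a lower number a stronger inhibitor), compound 2 `CC(C)N1CCc2nc(C#Cc3cccnc3)ccc2C1=O` gives 19600 nM, the highest number of the three measured, whereas compound 1 `CC(C)N1CCc2nc(C#Cc3cccc(Cl)c3)ccc2C1=O` gives 100 nM and compound 3 `CC(C)N1CCc2nc(C#Cc3cccs3)ccc2C1=O` gives 1930 nM. Every measured step changes the group on the triple-bonded carbon: a 200-fold higher number from compound 1 to compound 2 (2.29 log units; beyond the scatter), a 19-fold higher number from compound 1 to compound 3 (1.29 log units; beyond the scatter) and a 10-fold lower number from compound 2 to compound 3 (1.01 log units; beyond the scatter). Compound 4 `O=C1c2ccc(C#Cc3cccnc3)nc2CCN1C1CCCCC1` differs from compound 2 at a different place: cyclohexyl in place of isopropyl on an amide-type nitrogen in a ring. Among the compounds with values here, none of the measured steps touches the amide-type nitrogen, so the data give no guide to how this assay answers a change there, and the step expected from compound 2 to compound 4 is accordingly a 1.2-fold lower number from compound 2 to compound 4 (0.09 log units; within the scatter), none beyond the scatter. Compound 4 is therefore estimated at 16000 nM, with a range from 5000 nM to 50000 nM.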

Compound 4, inhibition constant: 15600 nM
Compound 4: the middle estimate sits 1.0-fold (0.01 log units) above what was measured; measured number inside the range.
By their numbers in this assay, from the lowest: compound 1; then compound 3; then compounds 4 and 2 (each within the scatter of the next).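

At the amide-type nitrogen in a ring, the first place outside the triple-bonded carbon to be probed, cyclohexyl in place of isopropyl gives a 1.3-fold lower number from compound 2 to compound 4 (0.10 log units; within the scatter) in this assay. Six carbons and a ring can therefore stand in place of three carbons without a change beyond the scatter, at least with pyridin-3-yl on the triple-bonded carbon. Nothing available here accounts for this result.

On these data alone, whether the same exchange behaves alike with 3-chlorophenyl on the triple-bonded carbon remains open. Also open, as far as these compounds go, is how this nitrogen would respond to a smaller methyl group, a longer chain ending in an amine, or a carboxylic acid.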